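Swapping the Aryl Group: From Naphthalene to Thiophene

The source may report more compounds than this note shows. Statements on the series, on what has been measured and on what is new or still open speak of the compounds shown alone.

Of the compounds shown here, three sharing one core have been tested in a functional assay on MOLT-4 cells (Homo sapiens) for inhibition, read by sulforhodamine B assay, with a stated time of 48 h, tested at 10 uM; on this read-out lower numbers stand for less inhibition and higher numbers for more inhibition at the one concentration tested (going by the name of the read-out). Compound 1 `O=Cc1ccc(-c2cn3ccnc3c(-c3ccc4ncn(C5CCCCC5)c4c3)n2)cc1` gives 58.7%. Compound 2 `c1ccc2c(-c3cn4ccnc4c(-c4ccc5ncn(C6CCCCC6)c5c4)n3)cccc2c1` gives 44.7%, and compound 3 `COc1ccccc1-c1cn2ccnc2c(-c2ccc3ncn(C4CCCCC4)c3c2)n1` gives 22.4%. Compound 2 thus stands second of the three: the step of a number 14 percentage points lower from compound 1 to compound 2 (beyond the scatter) places it beyond the scatter below compound 1, and the step of a number 22.3 percentage points lower from compound 2 to compound 3 (beyond the scatter) places it beyond the scatter above compound 3.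

Compound 4 `c1csc(-c2cn3ccnc3c(-c3ccc4ncn(C5CCCCC5)c4c3)n2)c1` differs from compound 2 in one place: thiophen-2-yl in place of naphthalen-1-yl on an aromatic carbon. The two measured steps that touch the same place, a number 14 percentage points lower from compound 1 to compound 2 (beyond the scatter) and a number 22.3 percentage points lower from compound 2 to compound 3 (beyond the scatter), were both modest drops, and the step of a number 36.3 percentage points lower from compound 1 to compound 3 (beyond the scatter) shows that exchanging one aryl group for another at that carbon can move the read-out by a large amount within this small set. Going by the values given here, no measured compound carries a five-membered ring at that place, so the direction for compound 4 is open. Given the spread among the three aryl groups already measured, a modest step in either direction seems as plausible as none. Compound 4 is therefore expected to give about 38% in this assay, within 18% to 58%, which would mean an expected step of a number 6.7 percentage points lower from compound 2 to compound 4 (within the scatter).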

Compound 4, a percentage reported as inhibition, at one concentration (the size of the read-out at that concentration, not a potency): 30.8%
The estimate for compound 4 lay 7.2 percentage points above the measured number; measured number inside the range.
By their numbers in this assay, from the lowest: compounds 3 and 4 (each within the scatter of the next); then compound 2; then compound 1.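

Replacing the two fused rings of naphthalen-1-yl with the single sulfur-containing ring of thiophen-2-yl gives a number 13.9 percentage points lower from compound 2 to compound 4 (beyond the scatter) in this assay and shows that a five-membered aromatic ring at this carbon does not keep the read-out at the level of compound 2. The step of a number 8.4 percentage points higher from compound 3 to compound 4 (within the scatter) means that thiophen-2-yl and 2-methoxyphenyl cannot be told apart here, even though one is a five-membered ring with sulfur and the other a phenyl ring carrying a methoxy group. Size alone does not set the order, since thiophen-2-yl has fewer heavy atoms than naphthalen-1-yl and reads lower, while the step of a number 27.9 percentage points lower from compound 1 to compound 4 (beyond the scatter) shows that 4-formylphenyl, also a single ring, reads well above thiophen-2-yl.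

The compounds shown leave open whether the high reading of compound 1 depends on its formyl group, a question that an amine or a carboxylic acid in place of that formyl group could test. Nothing measured here bears on why the read-out moves with these groups at this carbon.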